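A few compounds are considered here, and "the series" means these few. Any claim that something is new, unique, unknown or untested is made for them only; others in the source may bear on it.

Measured in a physicochemical assay for solubility, read by HPLC, in phosphate buffer, at pH 6.5; a lower number here means a less soluble compound, a higher number a more soluble compound:
- Compound 1 `COC(=O)C1=C(CN2CCCCC2)NC(c2nccs2)=NC1(C)c1ccc(F)cc1`: 282 ug/mL
- Compound 2 `COC(=O)C1=C(CN2CCNC(=O)C2)NC(c2nccs2)=NC1(C)c1ccc(F)cc1`: 34 ug/mL

Of these two compounds, compound 2 gives the lower number, and the gap lies beyond the scatter. Compound 3 `COC(=O)C1=C(CN2CCC(O)CC2)NC(c2nccs2)=NC1(C)c1ccc(F)cc1`, not yet measured, differs from compound 2 in one place: 4-hydroxypiperidin-1-yl in place of 3-oxopiperazin-1-yl on a saturated chain carbon bound to a double-bonded ring carbon. Within the data shown here, one measured step bears on this change: an 8.3-fold lower number from compound 1 to compound 2 (0.92 log units; beyond the scatter). That step brought in the same 3-oxopiperazin-1-yl, there in place of piperidin-1-yl. Among the measured compounds shown here, no measured compound carries 4-hydroxypiperidin-1-yl, so that step gives only a rough guide. A rise beyond the scatter is expected, somewhat smaller than the measured step. The estimated step is a 4.4-fold higher number from compound 2 to compound 3 (0.64 log units; beyond the scatter). For compound 3, the expected value in this assay is 150 ug/mL, with an estimated range of 50 ug/mL to 450 ug/mL.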

Compound 3, solubility: 593 ug/mL
Beside the measured number, compound 3's estimate is 4.0-fold (0.60 log units) below it; measured number outside the range, above it.
By their numbers in this assay, from the lowest: compound 2; then compound 1; then compound 3.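

In this assay, the position on a saturated chain carbon bound to a double-bonded ring carbon now shows a rise as well as a fall: replacing 3-oxopiperazin-1-yl with 4-hydroxypiperidin-1-yl gives a 17-fold higher number from compound 2 to compound 3 (1.24 log units; beyond the scatter). The two groups match in heavy atoms, hydrogen-bond donors and hydrogen-bond acceptors, so those counts do not separate the two results. Hydroxy in place of hydrogen on a saturated ring carbon of the piperidin-1-yl group gives a 2.1-fold higher number from compound 1 to compound 3 (0.32 log units; beyond the scatter), a modest step that still lies beyond the scatter.

No measurement is available that explains these differences. Whether the rise is specific to hydroxy remains open, since the compounds shown do not include an amine or a carboxylic acid on that saturated ring carbon.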